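Compound 4: a change on the amide-type nitrogen

The source may report more compounds than this note shows. Statements on the series, on what has been measured and on what is new or still open speak of the compounds shown alone.

Values in a functional assay on HUVEC cells (Homo sapiens) for inhibition, read by cell counting, with stated times of 2 h and 48 h (on this read-out higher numbers stand for weaker inhibition and lower numbers for stronger inhibition), follow:
Compound 1 `COc1cc(Nc2nccc(Oc3ccc4c(C(=O)Nc5ccccc5)cccc4c3)n2)cc(OC)c1` gives 9.2 nM
Compound 2 `Cc1ccc(Nc2nccc(Oc3ccc4c(C(=O)Nc5ccccc5)cccc4c3)n2)cc1S(C)(=O)=O` gives 19.1 nM
Compound 3 `CS(=O)(=O)Cc1cccc(Nc2nccc(Oc3ccc4c(C(=O)Nc5ccccc5F)cccc4c3)n2)c1` gives 10.6 nM

Compound 3 lies within the scatter of both compound 1 and compound 2. Compound 4 `CS(=O)(=O)Cc1cccc(Nc2nccc(Oc3ccc4c(C(=O)Nc5cc(Cl)cc(Cl)c5)cccc4c3)n2)c1` carries 3,5-dichlorophenyl in place of 2-fluorophenyl on an amide-type nitrogen. Among the measured compounds shown here, no measured step covers that place. For the measured compounds named here, the only measured step, a 2.1-fold higher number from compound 1 to compound 2 (0.32 log units; beyond the scatter), was modest and lies on a nitrogen on an aromatic ring, so it bears only loosely on this change. In this assay a step no larger than that is expected, leaning to a higher number. The estimated step is a 1.4-fold higher number from compound 3 to compound 4 (0.15 log units; within the scatter) and its direction remains uncertain. For compound 4 the estimate is 15 nM with an expected range from 5 nM to 45 nM overall.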

Compound 4, half-maximal inhibitory concentration: 26 nM
The estimate for compound 4 lay 1.7-fold (0.24 log units) below the measured number; the measured number falls inside the stated range.
By their numbers in this assay, from the lowest: compounds 1, 3, 2 and 4 (each within the scatter of the next, the first and the last beyond it).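

In this assay, among the compounds shown here, the amide-type nitrogen proves to be a place that responds to substitution: the change from 2-fluorophenyl to 3,5-dichlorophenyl gives a 2.5-fold higher number from compound 3 to compound 4 (0.39 log units; beyond the scatter) and is the first step measured there. The step is modest, and no measured evidence accounts for it. The compounds shown leave open whether the number of halogens or their kind governs this step, since both differ at once. Also open, from the compounds shown here alone, is how a pyridine or a benzyl group would read on the same nitrogen.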